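The compounds below may be only part of what the source reports. "The series", "measured", "known", "first", "only" and "open" are said of these compounds alone.

Measured so far, in a functional assay on HCC1806 cells (Homo sapiens) for inhibition, read by sulforhodamine B assay, tested at 10 uM; a higher number here means more inhibition at the concentration tested (going by the name of the read-out), a lower number less inhibition:
compound 1, `CN1CCN(c2ccc(C3=NN(C(=O)CCCl)C(c4ccc(N(C)C)cc4)C3)cc2)CC1`, gives 1.7%
compound 2, `CN(C)c1ccc(C2CC(c3ccc(-n4cncn4)cc3)=NN2C(=O)CCCl)cc1`, gives -3.4%

Compound 2 has the lower of these two numbers, but its nearest neighbour, compound 1, sits only a little higher, and the gap between them lies within the scatter of the method. Among the compounds with values here, the one measured step, a number 5.1 percentage points lower from compound 1 to compound 2 (within the scatter), therefore shows no real movement: swapping one ring for another at the same position on the six-membered carbon ring left the inhibition essentially where it was, near zero.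

Compound 3, `CN(C)c1ccc(C2CC(c3ccc(-n4ccnc4)cc3)=NN2C(=O)CCCl)cc1`, is not yet measured. It differs from compound 2 in one place: 1H-imidazol-1-yl in place of 1H-1,2,4-triazol-1-yl on an aromatic carbon. Within the data shown here, no measured step covers this exact exchange; the only step that bears on it is the one just described, which altered the same position by a different ring and stayed within the scatter. On that basis the step of a number 3.4 percentage points higher from compound 2 to compound 3 (within the scatter) is expected to remain within the scatter as well, with no clear direction. Compound 3 is therefore estimated to give about 0% in this assay, somewhere between -10% and 10%.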

Compound 3, a percentage reported as inhibition, at one concentration (the size of the read-out at that concentration, not a potency): -5.2%
Beside the measured number, compound 3's estimate is 5.2 percentage points above it, within the range that was stated.
By their numbers in this assay, from the lowest: compounds 3, 2 and 1 (each within the scatter of the next).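

At the aromatic carbon para to a large group, three different rings have now been read in this assay, and none stands apart: 1H-imidazol-1-yl in place of 1H-1,2,4-triazol-1-yl gives a number 1.8 percentage points lower from compound 2 to compound 3 (within the scatter), and 1H-imidazol-1-yl in place of 4-methylpiperazin-1-yl gives a number 6.9 percentage points lower from compound 1 to compound 3 (within the scatter). A five-membered aromatic ring with 2 hetero atoms and one with 3 hetero atoms therefore cannot be told apart here, and the same holds for 2 and 3 hydrogen-bond acceptors, so this exchange shows no direction at the concentration tested. No independent measurement is available to explain this flat picture.

All three readings lie close to zero, so these compounds cannot show whether this position can influence inhibition at all, or whether any effect of the ring is simply hidden when so little inhibition is seen. As far as these compounds go, it also remains open whether a non-ring group at the same place, such as a carboxylic acid or a primary amine, would give a reading clearly different from these three.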